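Removing One Fluoro Group from Compound 3

The source may report more compounds than this note shows. Statements on the series, on what has been measured and on what is new or still open speak of the compounds shown alone.

Three acids were tested in a toxicity assay on the whole organism (strain CD-1) for cytotoxicity, with Mus musculus as the target, with a stated time of 14 days, at a dose of 300 mg/kg by the intraperitoneal route; on this read-out lower numbers stand for a stronger effect and higher numbers for a weaker effect at the one dose given. Compound 1 `O=C(O)c1cc(F)c(F)c(F)c1O` gave 0% in this assay, and compound 2 `O=C(O)c1cc(F)c(F)cc1O` gave 33%. The difference between them, (hydrogen in place of fluoro on an aromatic carbon), went with a step of a number 33 percentage points higher from compound 1 to compound 2 (beyond the scatter). Compound 3 `CC(=O)Oc1c(C(=O)O)cc(F)c(F)c1F` gave 0%; here the difference from compound 1 is acetyl in place of hydrogen on an oxygen on an aromatic ring, and the step was no change at the digits printed from compound 1 to compound 3 (within the scatter), so compound 3 stands level with compound 1.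

Compound 4 `CC(=O)Oc1c(C(=O)O)ccc(F)c1F` has not yet been measured. It differs from compound 3 by hydrogen in place of fluoro on an aromatic carbon, and the two cores differ by acetyl in place of hydrogen on an oxygen on an aromatic ring. The surroundings of the changed carbon are not identical: in compound 1 it is ortho to a hydroxy group, whereas in compound 3 it is para to an acetoxy group, so this is the same kind of change rather than the same change. Removing the fluoro group from compound 1 gave a number 33 percentage points higher from compound 1 to compound 2 (beyond the scatter), and a comparable step is expected, a number 25 percentage points higher from compound 3 to compound 4 (beyond the scatter), resting on that one observation. Compound 4 is therefore estimated at 25%, with a likely range from 0% to 50%.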

Compound 4, a percentage reported as activity, at one dose (the size of the read-out at that dose, not a potency): 33%
Beside the measured number, compound 4's estimate is 8 percentage points below it; measured number inside the range.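

In this assay, putting hydrogen in place of the fluoro group on the acetoxy core gave a number 33 percentage points higher from compound 3 to compound 4 (beyond the scatter). Set beside the same change on the hydroxy core, the step carried over without a difference in size: the same change on two cores in this assay, a number 33 percentage points higher (beyond the scatter) from compound 1 to compound 2 and a number 33 percentage points higher (beyond the scatter) from compound 3 to compound 4, 0 percentage points apart, within the scatter of two such steps. This shows that, for these two pairs at this one dose, the change behaved alike whether the oxygen carried hydrogen or acetyl, but it does not show why the step arises or that it would hold on any other core.

The compounds shown leave open whether removing either of the other fluoro groups would give a step of similar size, and whether a chlorine atom or a methyl group in that place would behave like hydrogen. They also leave open whether the step would survive on a core carrying a longer acyl chain on the oxygen, or an amide in place of the carboxy group.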